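A few compounds are considered here, and "the series" means these few. Any claim that something is new, unique, unknown or untested is made for them only; others in the source may bear on it.

Compound 1 `Oc1cccc(-c2cc(-c3ccccc3F)cc(-c3ccccc3O)n2)c1` gives 8470 nM in a functional assay on HCT-15 cells (Homo sapiens) for inhibition; a higher number here means a weaker inhibitor, a lower number a stronger inhibitor. Compound 2 `Oc1cccc(-c2cc(-c3cccc(F)c3)cc(-c3ccccc3O)n2)c1` is reported in this assay only as a limit, > 50000 nM, not as a number (the limit of > 50000 nM in this assay, at which 1 of the 3 values shown sits). The change 3-fluorophenyl in place of 2-fluorophenyl on an aromatic carbon therefore gives an at least 5.9-fold higher number from compound 1 to compound 2 (0.77 log units; beyond the scatter). Compound 3 `Oc1cccc(-c2cc(-c3ccccc3F)cc(-c3cccc(O)c3)n2)c1` gives 5300 nM in this assay; the change 3-hydroxyphenyl in place of 2-hydroxyphenyl on an aromatic carbon gives a 1.6-fold lower number from compound 1 to compound 3 (0.20 log units; within the scatter), and this is also how the cores of compound 1 and compound 3 differ. Compound 4 `Oc1cccc(-c2cc(-c3cccc(F)c3)cc(-c3cccc(O)c3)n2)c1` is not yet measured. It differs from compound 3 by 3-fluorophenyl in place of 2-fluorophenyl on an aromatic carbon, the same kind of change as from compound 1 to compound 2, though not the same: there the place was meta to a 2-hydroxyphenyl group and meta to a 3-hydroxyphenyl group, here it is meta to two 3-hydroxyphenyl groups. A step of a 6.6-fold higher number from compound 3 to compound 4 (0.82 log units; beyond the scatter) is expected in this assay, resting on the measured step of an at least 5.9-fold higher number from compound 1 to compound 2 (0.77 log units; beyond the scatter). Compound 4 is estimated at 35000 nM, roughly 12000 nM to 100000 nM, with a fair chance that only a limit is reported.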

Compound 4, half-maximal inhibitory concentration: 7860 nM
For compound 4 the middle estimate is 4.5-fold (0.65 log units) above the measured one, outside the stated range (below it).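

The change to 3-fluorophenyl from 2-fluorophenyl does not carry over unchanged between these two cores in this assay: on the core of compound 3 it gives a 1.5-fold higher number from compound 3 to compound 4 (0.17 log units; within the scatter), and the two steps differ: the same change on two cores in this assay, an at least 5.9-fold higher number (0.77 log units; beyond the scatter) from compound 1 to compound 2 and a 1.5-fold higher number (0.17 log units; within the scatter) from compound 3 to compound 4, at least 3.9-fold (0.59 log units) apart, beyond the scatter of two such steps. The change to 3-hydroxyphenyl from 2-hydroxyphenyl likewise depends on the core, giving an at least 6.3-fold lower number from compound 2 to compound 4 (0.80 log units; beyond the scatter), and again the two steps differ: the same change on two cores in this assay, a 1.6-fold lower number (0.20 log units; within the scatter) from compound 1 to compound 3 and an at least 6.3-fold lower number (0.80 log units; beyond the scatter) from compound 2 to compound 4, at least 3.9-fold (0.59 log units) apart, beyond the scatter of two such steps. Compound 2 is reported only as a limit, > 50000 nM, so the two changes are shown not to act independently here, but the size of their interaction remains unread.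

As far as these compounds go, whether this dependence extends beyond fluorine and hydroxy groups remains open. An amine or a carboxylic acid in place of the hydroxy groups, or chlorine in place of fluorine, could test it.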